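Amide nitrogen substituents and cytotoxicity on the shared core

A few compounds are considered here, and "the series" means these few. Any claim that something is new, unique, unknown or untested is made for them only; others in the source may bear on it.

Compound 1 `C=C(CC)C(=O)c1ccc(OCC(=O)Nc2nc3ccccc3s2)c(Cl)c1Cl` gives 1500 nM
Compound 2 `C=C(CC)C(=O)c1ccc(OCC(=O)NC(CS)C(=O)OCC)c(Cl)c1Cl` gives 4800 nM
Compound 3 `C=C(CC)C(=O)c1ccc(OCC(=O)Nc2ccc(C(C)=O)cc2)c(Cl)c1Cl` gives 3900 nM

In a functional assay on CLL cells (Homo sapiens) for cytotoxicity, read by MTT assay, with a stated time of 48 h (a lower number here means that less compound is needed, a higher number that more compound is needed for the effect), compound 3 stands in the upper pair of the three numbers, level with compound 2 within the scatter. The next change leads to compound 4 `C=C(CC)C(=O)c1ccc(OCC(=O)NCCO)c(Cl)c1Cl` and puts 2-hydroxyethyl in place of 4-acetylphenyl on an amide-type nitrogen with the core unchanged. The closest measured precedent is a 1.2-fold lower number from compound 2 to compound 3 (0.09 log units; within the scatter) and it stays within the scatter. The two larger steps, a 3.2-fold higher number from compound 1 to compound 2 (0.51 log units; beyond the scatter) and a 2.6-fold higher number from compound 1 to compound 3 (0.41 log units; beyond the scatter), both remove 1,3-benzothiazol-2-yl, a group not involved here. No step beyond the scatter is therefore expected in this assay and the estimated step is a 1.1-fold higher number from compound 3 to compound 4 (0.03 log units; within the scatter). Compound 4 is expected at 4200 nM, with an estimated range of 1800 nM to 9500 nM.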

Compound 4, half-maximal effective concentration: > 25000 nM
Compound 4: a limit, no number; the forecaster's own chance of this, stated with the estimate: 3%; middle value at least 5.9-fold (0.77 log units) from the limit.
By their numbers in this assay, from the lowest: compound 1; then compounds 3 and 2 (each within the scatter of the next). At a limit, above all of these: compound 4.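

In this assay, the amide-type nitrogen substituent proves able to shift the number well beyond the scatter among non-benzothiazole groups: 2-hydroxyethyl gives an at least 6.4-fold higher number from compound 3 to compound 4 (0.80 log units; beyond the scatter), an at least 5.2-fold higher number from compound 2 to compound 4 (0.71 log units; beyond the scatter) and an at least 16-fold higher number from compound 1 to compound 4 (1.22 log units; beyond the scatter). The value of compound 4 is a limit, not a number: the limit of > 25000 nM in this assay, at which 1 of the 4 values shown sits. Compound 2 carries no ring on this nitrogen yet gives a measured number, so the loss of the ring in 4-acetylphenyl does not by itself account for the result.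

On these data alone, whether the hydroxyl group or the short chain sets compound 4 apart remains open. A simple ethyl group, a longer chain ending in hydroxyl or a chain ending in an amine would separate these.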